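The source may report more compounds than this note shows. Statements on the series, on what has been measured and on what is new or still open speak of the compounds shown alone.

Measured so far in an ADME assay on HS27 cells (Homo sapiens) for cytotoxicity, read by MTT assay, with a stated time of 24 h; on this read-out higher numbers stand for weaker inhibition of growth and lower numbers for stronger inhibition of growth:

- Compound 1 `Cc1ccc(NC(=O)Nc2ccccc2F)cc1NC(=O)c1cnoc1C` gives > 30000 nM (a limit)
- Compound 2 `Cc1ccc(NC(=O)Nc2ccc(Cl)c(Cl)c2)cc1NC(=O)c1cnoc1C` gives > 30000 nM (a limit)
- Compound 3 `Cc1cc(NC(=O)Nc2cccc(Cl)c2)ccc1NC(=O)c1cnoc1C` gives > 30000 nM (a limit)

Compound 3 therefore has no exact number, and all three compounds share (the limit of > 30000 nM in this assay, at which 3 of the 3 values shown sit).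

Compound 4 `Cc1cc(NC(=O)Nc2ccc(Cl)c(Cl)c2)ccc1NC(=O)c1cnoc1C` differs from compound 3 by chloro in place of hydrogen on an aromatic carbon, which turns 3-chlorophenyl into 3,4-dichlorophenyl. Among the measured compounds shown here, the one measured step that bears on this is a step that the two limits leave unreadable from compound 1 to compound 2, which brings in the same 3,4-dichlorophenyl group on a different core. It gives no size to carry over, so no step beyond the scatter is expected in this assay. The expected change is a number no higher from compound 3 to compound 4 (the limit leaves the size open) and is only an estimate. Compound 4 is estimated at 30000 nM (expected range 12000 nM to 60000 nM) and may well be reported only as a limit.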

Compound 4, concentration for 50% growth inhibition: > 30000 nM
Compound 4: no number, only a limit (the forecaster's own chance of this, stated with the estimate: 85%); the middle value sits exactly at the limit.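

No step can be read from compound 3 to compound 4, because both are reported only as limits: the limit of > 30000 nM in this assay, at which 4 of the 4 values shown sit.

The compounds shown leave open what exact number any of them would give, and so whether the added chloro changes anything.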